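This account rests on a few compounds, and the source may have more. Where it says the series, first, only, none or still open, it means among the compounds named here.

Three compounds built on one shared core have been run through an ADME assay on PC-3 cells (Homo sapiens) for cytotoxicity, read by sulforhodamine B assay, with a stated time of 48 h, tested at 10 uM; on this read-out lower numbers stand for less inhibition and higher numbers for more inhibition at the one concentration tested (going by the name of the read-out). Compound 1, `COc1nc2ccc(Br)cc2cc1C(c1ccccc1)n1cc(-c2ccccc2)nn1`, gives 5.97% in this assay. Compound 2, `COc1nc2ccc(Br)cc2cc1C(c1ccccc1)n1cc(-c2ccccc2C(F)(F)F)nn1`, gives 17.4%, and the step of a number 11.4 percentage points higher from compound 1 to compound 2 (beyond the scatter) follows from trifluoromethyl in place of hydrogen on an aromatic carbon. Compound 3, `COc1nc2ccc(Br)cc2cc1C(c1ccccc1)n1cc(CCCCCO)nn1`, gives 12.9%; it stands second highest of the three, with compound 2 nearest and compound 1 furthest, and both the step of a number 6.9 percentage points higher from compound 1 to compound 3 (within the scatter) and the step of a number 4.5 percentage points lower from compound 2 to compound 3 (within the scatter) lie within the scatter.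

Compound 4, `COc1nc2ccc(Br)cc2cc1C(c1ccccc1)n1cc(C2CC2)nn1`, is the next one to be measured. It differs from compound 3 as follows: cyclopropyl in place of 5-hydroxypentyl on an aromatic carbon. Within the data shown here, no measured step bears directly on this exchange; the only steps touching the same aromatic carbon are those from compound 1 and compound 2 to compound 3, and both are within the scatter. The three values already measured all lie close together. The expectation for compound 4 is therefore a step of a number 2.9 percentage points lower from compound 3 to compound 4 (within the scatter), no larger than the scatter. Compound 4 is estimated at 10%, within a range from 0% to 22%.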

Compound 4, a percentage reported as inhibition, at one concentration (the size of the read-out at that concentration, not a potency): 22.6%
The estimate for compound 4 lay 12.6 percentage points below the measured number, outside the stated range (above it).
By their numbers in this assay, from the lowest: compounds 1, 3, 2 and 4 (each within the scatter of the next, the first and the last beyond it).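

Among these compounds, exchanging phenyl for cyclopropyl on this aromatic carbon gives a number 16.6 percentage points higher from compound 1 to compound 4 (beyond the scatter) in this assay, the first change of the group at this position that lies beyond the scatter, since the exchange for 5-hydroxypentyl did not. The same cyclopropyl gives a number 9.7 percentage points higher from compound 3 to compound 4 (within the scatter) and a number 5.2 percentage points higher from compound 2 to compound 4 (within the scatter), so it is not separated from either 5-hydroxypentyl or 2-(trifluoromethyl)phenyl, and only phenyl stands apart from it. Nothing measured here accounts for the difference between cyclopropyl and phenyl.

As far as these compounds go, whether an amine, a carboxylic acid or a cyclobutyl ring on this carbon would give a number beyond the scatter from compound 4 remains open. Also open, from the compounds shown here alone, is how these compounds would compare at other concentrations, since a single concentration gives no potency.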